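The source may report more compounds than this note shows. Statements on the series, on what has been measured and on what is new or still open speak of the compounds shown alone.

In a functional assay on CHO cells for agonist activity at Alpha-1D adrenergic receptor (Homo sapiens), read by FLIPR and calcium flux (a lower number here means that less compound is needed, a higher number that more compound is needed for the effect), compound 1, with structure `c1ccc2c(c1)CCC2c1ncc[nH]1`, reaches only the limit of the assay, > 10000 nM. Compound 2, with structure `CNC(=O)c1cccc2c1CCC2c1ncc[nH]1`, likewise stops at the limit > 10000 nM. Within the data shown here, the single measured step, a step that the two limits leave unreadable from compound 1 to compound 2, cannot be read because both ends sit at the limit of > 10000 nM in this assay, at which 2 of the 2 values shown sit. Compound 3, with structure `c1cc(-c2ncco2)c2c(c1)C(c1ncc[nH]1)CC2`, has not yet been measured; it differs from compound 2 by 1,3-oxazol-2-yl in place of methylcarbamoyl on an aromatic carbon. Among the measured compounds shown here, the one measured step bears on this change only in that both of its ends lie beyond the limit, and since its size is unknown, no direction can be drawn from it. For compound 3 the estimated step that the limit leaves unreadable from compound 2 to compound 3 is expected to stay within the scatter, so that compound 3 would again be expected to sit at the limit. The estimate for compound 3 is 15000 nM, with a range from 5000 nM to 60000 nM.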

Compound 3, half-maximal effective concentration: 1390 nM
Compound 3: the middle estimate sits 11-fold (1.03 log units) above what was measured; measured number outside the range, below it.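

In this assay, the 1,3-oxazol-2-yl group gives the shared core its first readable value in this series. Putting it in place of methylcarbamoyl gives an at least 7.1-fold lower number from compound 2 to compound 3 (0.85 log units; beyond the scatter) and putting it in place of hydrogen on the same aromatic carbon gives an at least 7.1-fold lower number from compound 1 to compound 3 (0.85 log units; beyond the scatter) so this carbon can carry a group that brings a measurable response, while methylcarbamoyl there showed none within the limit. Both steps give only a minimum size, and the step between the two limits remains unreadable, because compound 1 and compound 2 are not exact numbers: the limit of > 10000 nM in this assay, at which 2 of the 3 values shown sit.

The compounds shown cannot separate the effect of the ring as a whole from that of its particular hetero atoms, as a phenyl or thiazol-2-yl ring at this carbon could. They also leave open whether a small amine here would give a readable value, and whether 1,3-oxazol-2-yl would do so on another aromatic carbon.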